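Selenium to tellurium exchange in the series

This account rests on a few compounds, and the source may have more. Where it says the series, first, only, none or still open, it means among the compounds named here.

In a functional assay on SK-MEL-147 cells (Homo sapiens) for cytotoxicity, read by MTT assay, with a stated time of 24 h (a lower number here means that less compound is needed, a higher number that more compound is needed for the effect), compound 1 (`CCCCC#Cc1cc(C(=O)OCC)nc2ccc(OC)cc12`) gives 7200 nM and compound 2 (`CCOC(=O)c1cc([Se]c2ccccc2)c2cc(OC)ccc2n1`) gives 33000 nM, the higher of the two numbers. Compound 3 (`CCOC(=O)c1cc([Te]c2ccccc2)c2cc(OC)ccc2n1`) is not yet measured. It differs from compound 2 by a group of 7 heavy atoms (6 carbon, 1 tellurium; one six-membered aromatic ring of carbon only) in place of a group of 7 heavy atoms (6 carbon, 1 selenium; one six-membered aromatic ring of carbon only), on an aromatic carbon, opposite the ring nitrogen. Among the compounds with values here, the only measured step, a 4.6-fold higher number from compound 1 to compound 2 (0.66 log units; beyond the scatter), is a different exchange on an aromatic carbon, and no measured step swaps selenium for tellurium, so it gives a scale but no direction. In this assay, a tentatively lower number is expected, a 2.8-fold lower number from compound 2 to compound 3 (0.44 log units; beyond the scatter), no larger than that measured step. For compound 3 the estimate is 12000 nM, with a range of 3000 nM to 40000 nM.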

Compound 3, half-maximal effective concentration: 128000 nM
Beside the measured number, compound 3's estimate is 11-fold (1.03 log units) below it; the measured number lies above the stated range.
By their numbers in this assay, from the lowest: compound 1; then compound 2; then compound 3.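

Exchanging selenium for tellurium on the aromatic carbon opposite the ring nitrogen, with the six-membered aromatic ring of carbon only unchanged, gives a 3.9-fold higher number from compound 2 to compound 3 (0.59 log units; beyond the scatter) in this assay, so the linking atom alone moves the number. The tellurium group also stands further from the ringless group of compound 1, with an 18-fold higher number from compound 1 to compound 3 (1.25 log units; beyond the scatter). No available data account for either step.

Open, on these data alone, is whether a sulfur or oxygen link at this position would extend the same trend. Also open, as far as these compounds go, is whether an amine there would give a lower number than the ringless group.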